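The compounds below may be only part of what the source reports. "The series", "measured", "known", "first", "only" and "open" are said of these compounds alone.

The measured compounds in an assay on CHO cells for antagonist activity at transient receptor potential cation channel subfamily V member 1 (Homo sapiens), read by FLIPR; a higher number here means a weaker inhibitor, a lower number a stronger inhibitor:

compound 1, `CC(C(=O)NCc1ccc(C(F)(F)F)cc1N1CCCCCCC1)c1ccc(NS(C)(=O)=O)c(F)c1`, gives 2.8 nM
compound 2, `CC(C(=O)NCc1ccc(C(F)(F)F)cc1OC1CCCC1)c1ccc(NS(C)(=O)=O)c(F)c1`, gives 0.6 nM
compound 3, `C[C@H](C(=O)NCc1ccc(C(F)(F)F)cc1SC1CCCCC1)c1ccc(NS(C)(=O)=O)c(F)c1`, gives 0.3 nM

Within this set compound 2 holds the second highest of the three numbers. Its nearest neighbour is compound 3, whose value lies within the scatter of that of compound 2, so no order between the two can be read; its furthest is compound 1, which sits beyond the scatter on the higher side.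

Compound 4 is `CC(C(=O)NCc1ccc(C(F)(F)F)cc1SCc1ccco1)c1ccc(NS(C)(=O)=O)c(F)c1`. It differs from compound 2 in one place: ((furan-2-yl)methyl)sulfanyl in place of cyclopentyloxy on an aromatic carbon.

For the measured compounds named here, only one measured step touches this position: a 4.7-fold lower number from compound 1 to compound 2 (0.67 log units; beyond the scatter), a modest drop in the number when the cyclopentyloxy group replaced the eight-membered ring. Compounds 2 and 3 also differ at the same place, and their two values show a gap within the scatter, so exchanging groups there has so far moved the number by little once the cyclopentyloxy group is present. On that basis the change to the ((furan-2-yl)methyl)sulfanyl group is expected to leave the number near that of compound 2, with any step a 1.2-fold lower number from compound 2 to compound 4 (0.08 log units; within the scatter) likely within the scatter. Compound 4 is therefore estimated at 0.5 nM, with a range from 0.15 nM to 2 nM.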

Compound 4, inhibition constant: 3.2 nM
Compound 4: middle estimate off by 6.4-fold (0.81 log units), on the low side; measured number above the stated range.
By their numbers in this assay, from the lowest: compounds 3 and 2 (each within the scatter of the next); then compounds 1 and 4 (each within the scatter of the next).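

In this assay the ((furan-2-yl)methyl)sulfanyl group brings a 5.3-fold higher number from compound 2 to compound 4 (0.73 log units; beyond the scatter), so this position on the aromatic carbon does not keep the number steady across groups, as the closeness of compound 2 and compound 3 alone might have suggested. The new group also lands level with the eight-membered ring, with a 1.1-fold higher number from compound 1 to compound 4 (0.06 log units; within the scatter), so two very different groups give the same result here, and both sit on the higher side of the set. Sulfur at this place does not by itself fix the number: compound 3 also carries sulfur and gives 0.3 nM, while compound 4 gives 3.2 nM.

Nothing available here explains why the number rises with the ((furan-2-yl)methyl)sulfanyl group. Going by these compounds, it remains open whether the rise follows the furan ring or the methylene link to the sulfur, a question that a benzylsulfanyl group and a cyclopentylsulfanyl group at this same place would help to separate.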